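This account rests on a few compounds, and the source may have more. Where it says the series, first, only, none or still open, it means among the compounds named here.

Measured so far:
compound 1 `CCCCC(Sc1ccc(OCCCOc2cccc3c2CCCC3)cc1)C(=O)OCC` — > 10000 nM
compound 2 `CCCCC(Sc1ccc(OCCCOc2ccc(Cl)cc2OC)cc1)C(=O)O` — > 10000 nM

In an assay on isolated protein for inhibition of Polyunsaturated fatty acid 5-lipoxygenase (Homo sapiens), read by HPLC, with a stated time of 15 min, in the presence of a further agent that is not named here (a lower number here means a stronger inhibitor, a higher number a weaker inhibitor), compound 1 gives > 10000 nM, which is a limit of the assay and not a number. Compound 2 gives > 10000 nM, likewise a limit. Both readings sit at the limit of > 10000 nM in this assay, at which 2 of the 2 values shown sit, so compound 2 has no measured inhibition to stand on. Compound 3 `CCCCC(Sc1ccc(OCCCOc2cccc(C(C)C)c2)cc1)C(=O)O` differs from compound 2 by 3-isopropylphenyl in place of 4-chloro-2-methoxyphenyl on an oxygen on a saturated carbon. For the measured compounds named here, no step between measured compounds is known here, so the expected step that the limit leaves unreadable from compound 2 to compound 3 is none beyond the scatter, most likely another limit. Compound 3 is therefore estimated at 15000 nM, with a range from 4000 nM to 60000 nM.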

Compound 3, half-maximal inhibitory concentration: 1400 nM
Compound 3: the middle estimate sits 11-fold (1.03 log units) above what was measured; the whole stated range lies above it.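

With 3-isopropylphenyl in place of 4-chloro-2-methoxyphenyl on an oxygen on a saturated carbon, this assay shows an at least 7.1-fold lower number from compound 2 to compound 3 (0.85 log units; beyond the scatter). For the compounds shown here, this is the first sign that the group at this position can move the reading off the limit, and the all-carbon 3-isopropylphenyl carries no hydrogen-bond acceptor. The true size of the step stays unknown, as compound 2 gives only a limit: the limit of > 10000 nM in this assay, at which 2 of the 3 values shown sit.

The compounds shown leave open whether the change comes from gaining the isopropyl group or from losing the chlorine or the methoxy group. Going by these compounds, how a tert-butyl or cyclohexyl group would read at this position also remains open.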